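Changing the Aromatic End of Compound 3

This account rests on a few compounds, and the source may have more. Where it says the series, first, only, none or still open, it means among the compounds named here.

In a functional assay on Raji cells (Homo sapiens) for antiproliferative activity, read by MTT assay, with a stated time of 72 h (a lower number here means a stronger inhibitor, a higher number a weaker inhibitor), compound 3 (`CN(Cc1nc(C2CCN(Cc3ccccc3F)CC2)no1)c1ncc(C(=O)NO)cn1`) gives 98.6 nM as the lowest of three numbers. Compound 2 (`Cc1ccc(CN2CCC(c3noc(CN(C)c4ncc(/C=C/C(=O)NO)cn4)n3)CC2)cc1`) gives 293 nM and compound 1 (`CN(Cc1nc(C2CCN(Cc3ccccc3)CC2)no1)c1ncc(/C=C/C(=O)NO)cn1`) gives 547 nM and both lie beyond the usual scatter from compound 3. Compound 3 differs from those two in more than one place, so these gaps cannot be tied to any single structural change.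

The compound still awaiting measurement is compound 4 (`CN(Cc1nc(C2CCN(Cc3ccc(C(F)(F)F)cc3)CC2)no1)c1ncc(C(=O)NO)cn1`). It carries 4-(trifluoromethyl)phenyl in place of 2-fluorophenyl on a saturated chain carbon bound to an amine nitrogen in a ring. Cut one bond further out, the same difference reads 2-fluorobenzyl to 4-(trifluoromethyl)benzyl.

Among the compounds with values here, no measured pair makes this exact swap. Within the data shown here, the only measured step that bears on it is a 1.9-fold lower number from compound 1 to compound 2 (0.27 log units; within the scatter) with methyl in place of hydrogen on an aromatic carbon. A single step is thin evidence, and it comes from compounds that differ from compound 3 elsewhere too, but it offers no ground for expecting a real shift in either direction. The expected change is a 1.2-fold higher number from compound 3 to compound 4 (0.09 log units; within the scatter) and so no step beyond the scatter is expected in this assay for this swap. The estimate for compound 4 is 120 nM within an expected range of 45 nM to 300 nM for a single measurement.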

Compound 4, half-maximal inhibitory concentration: 207 nM
Estimate against measurement, compound 4: 1.7-fold (0.24 log units) below; low and high end bracket the measured number.
By their numbers in this assay, from the lowest: compound 3; then compounds 4, 2 and 1 (each within the scatter of the next, the first and the last beyond it).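

In this assay, replacing 2-fluorophenyl with 4-(trifluoromethyl)phenyl gives a 2.1-fold higher number from compound 3 to compound 4 (0.32 log units; beyond the scatter) and so shows that this aromatic end can shift the number, if only modestly. Within the data shown here, the one earlier single-place step, a 1.9-fold lower number from compound 1 to compound 2 (0.27 log units; within the scatter), stayed within the scatter and could not show this, although it comes from compounds with a different link to the hydroxamic acid, so the two steps are not the same test of this position. Nothing measured here explains why the number rose from compound 3 to compound 4.

This swap changes both the group on the phenyl ring and where that group sits, so the compounds shown cannot separate the two changes; 2-(trifluoromethyl)phenyl or 4-fluorophenyl on the same core would be needed to tell them apart. Going by these compounds, it also remains open how this end would respond to groups of quite another kind, such as a nitrile, an amine or a carboxylic acid on the phenyl ring, or to a longer chain linking that ring to the ring nitrogen.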